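The compounds below may be only part of what the source reports. "The series", "measured", "known", "first", "only" and "open" are said of these compounds alone.

Measured in a functional assay on SK-MEL-28 cells (Homo sapiens) for inhibition, read by colorimetric assay and MTT assay, with a stated time of 72 h; on this read-out higher numbers stand for weaker inhibition and lower numbers for stronger inhibition:
Compound 1 `COc1ccc2c(c1)-c1cnc(n1C)OCCCCCCCCO2`: 57000 nM
Compound 2 `C=CCCCCOc1ccccc1-c1cnc(OCCC=C)n1C`: 17000 nM
Compound 3 `C=CCCCCOc1ccccc1-c1cnc(OCCCC=C)n1C`: 19000 nM

Compound 3, at 19000 nM, lies within the scatter of compound 2, and its number is lower than that of compound 1. Compound 4 `C=CCCCCOc1ccccc1-c1cnc(OCCCCC=C)n1C` is still to be measured in this assay. It differs from compound 3 as follows: allyl in place of vinyl on a saturated chain carbon, three bonds along the chain from an oxygen on an aromatic ring. The change places allyl in place of vinyl, turning pent-4-en-1-yl into hex-5-en-1-yl. Among the compounds with values here, only one measured step bears on it, the same exchange one bond nearer the oxygen: a 1.1-fold higher number from compound 2 to compound 3 (0.05 log units; within the scatter). No step beyond the scatter is therefore expected. The expected step, a 1.1-fold higher number from compound 3 to compound 4 (0.02 log units; within the scatter), is an estimate that stays within the scatter. For compound 4 the estimated value is 20000 nM, with an expected range of 10000 nM to 38000 nM.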

Compound 4, half-maximal inhibitory concentration: 5000 nM
For compound 4 the middle estimate is 4.0-fold (0.60 log units) above the measured one; measured number outside the range, below it.
By their numbers in this assay, from the lowest: compound 4; then compounds 2 and 3 (each within the scatter of the next); then compound 1.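

In this assay, this position first responds to chain length at hex-5-en-1-yl: the earlier exchange gave only a 1.1-fold higher number from compound 2 to compound 3 (0.05 log units; within the scatter), whereas this one gives a 3.8-fold lower number from compound 3 to compound 4 (0.58 log units; beyond the scatter). Measured across both extensions, the change from but-3-en-1-yl to hex-5-en-1-yl gives a 3.4-fold lower number from compound 2 to compound 4 (0.53 log units; beyond the scatter), so the response across these three compounds is uneven rather than stepwise. No available evidence accounts for this change in response. From the compounds shown here alone, whether a longer chain, such as hept-6-en-1-yl, would lower the number further remains open. So does whether the terminal double bond matters, which a saturated hexyl chain would test.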